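A Fluoro Swap on a Weakly Active Compound

The source may report more compounds than this note shows. Statements on the series, on what has been measured and on what is new or still open speak of the compounds shown alone.

In a functional assay on PC-3 cells (Homo sapiens) for inhibition, read by MTT assay, with a stated time of 48 h, tested at 10 uM (on this read-out lower numbers stand for less inhibition of growth and higher numbers for more inhibition of growth at the one concentration tested), compound 1 (`Cc1cc(=O)c2c(O)c(CN(C(C)C)C(C)C)c(O)c([C@H]3CCN(C)C[C@H]3O)c2o1`) gives 0% inhibition and compound 2 (`CN1CC[C@H](c2c(O)cc(O)c3c(=O)cc(/C=C/c4ccccc4)oc23)[C@H](O)C1`) gives 10% inhibition. These two numbers lie within the usual scatter of each other, so neither compound can be ranked over the other, and both do little to growth at this one concentration. Compound 3 (`CN1CC[C@H](c2c(O)cc(O)c3c(=O)cc(/C=C/c4cccc(F)c4)oc23)[C@H](O)C1`) differs from compound 2 by one small edit (fluoro in place of hydrogen on an aromatic carbon) with fluoro in place of hydrogen on an aromatic carbon, turning 2-phenylethenyl into 2-(3-fluorophenyl)ethenyl. For the measured compounds named here, no measured pair yet shows what a single edit of this kind does. In this assay, going by the values given here, no step beyond the scatter is expected, in neither direction, and the only anchor is compound 2 at 10% on this scale. The estimate amounts to a number 2 percentage points higher from compound 2 to compound 3 (within the scatter) and this expected shift stays within the scatter. Compound 3 is expected to give 12% inhibition, with an estimated range from 0% to 30% in this measurement.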

Compound 3, percent growth inhibition at one concentration: 67%
Compound 3: middle estimate off by 55 percentage points, on the low side; the whole stated range lies below it.
By their numbers in this assay, from the lowest: compounds 1 and 2 (each within the scatter of the next); then compound 3.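

Replacing one hydrogen with fluoro on the aromatic ring of the 2-phenylethenyl group gives a number 57 percentage points higher from compound 2 to compound 3 (beyond the scatter) in this assay. This position is therefore sensitive to a very small edit: the change adds one heavy atom, with no ring, no net charge and no hydrogen-bond donors or acceptors, yet compound 3 clearly inhibits growth at the one concentration tested. Nothing measured here explains why this single swap has so large an effect.

The compounds shown leave open whether the gain belongs to fluoro itself or to this place on the ring, a question that chloro or methoxy at the same carbon, or fluoro at another carbon of the ring, would address. They also leave open how compound 3 behaves at other concentrations.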